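Trimming the imine arm of a serine lipoamide

The source may report more compounds than this note shows. Statements on the series, on what has been measured and on what is new or still open speak of the compounds shown alone.

Measured so far:
Compound 1, `CCCCCCCCCCCCCCNC(=O)[C@H](CO)NC(=O)C1CCCCC1`: 7200 nM
Compound 2, `CCCCCCCCCCCCCCNC(=O)[C@H](CO)/N=C/c1ccccc1`: 4700 nM

In a functional assay on MCF7 cells (Homo sapiens) for inhibition, read by microscopy and colony formation, with a stated time of 10 days (a lower number here means a stronger inhibitor, a higher number a weaker inhibitor), compound 1 gives 7200 nM and compound 2 gives 4700 nM. Compound 2 stands with compound 1 within the scatter: a 1.5-fold lower number from compound 1 to compound 2 (0.19 log units; within the scatter). Compound 3, `CCCCCCCCCCCCCCNC(=O)[C@H](CO)NC(C)=O`, departs from compound 2 by one change: a group of 4 heavy atoms (2 carbon, 1 nitrogen, 1 oxygen; no ring) in place of a group of 8 heavy atoms (7 carbon, 1 nitrogen; one six-membered aromatic ring of carbon only), on a saturated chain carbon bound to a carbonyl carbon and a saturated chain carbon. Within the data shown here, no measured step mirrors this change; the only step known, a 1.5-fold lower number from compound 1 to compound 2 (0.19 log units; within the scatter), replaces a group of 9 heavy atoms with a group of 8 heavy atoms and stays within the scatter, so it offers little guidance. Compound 3 is therefore expected to sit near its neighbours or somewhat weaker, a 2.1-fold higher number from compound 2 to compound 3 (0.33 log units; beyond the scatter). The estimate for compound 3 is 10000 nM, within 4000 nM to 25000 nM.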

Compound 3, half-maximal inhibitory concentration: 44700 nM
Estimate against measurement, compound 3: 4.5-fold (0.65 log units) below, and the stated range ends below it.
By their numbers in this assay, from the lowest: compounds 2 and 1 (each within the scatter of the next); then compound 3.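

In this assay, this position turns out to respond to the group it carries: acetamido in place of the aromatic imine arm gives a 9.5-fold higher number from compound 2 to compound 3 (0.98 log units; beyond the scatter) and the amide series shows the same direction, with methyl in place of cyclohexyl on a carbonyl carbon giving a 6.2-fold higher number from compound 1 to compound 3 (0.79 log units; beyond the scatter) in the same assay. The two ring-bearing groups had stayed within the scatter of each other, so only the ringless group separates from them. Nothing on hand accounts for this loss. The compounds shown leave open whether a ring itself matters or only the size of the group. A cyclopropyl or an n-butyl on the same carbonyl carbon would bear on that, and a phenyl there would bear on whether the imine and amide links differ.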